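This account rests on a few compounds, and the source may have more. Where it says the series, first, only, none or still open, it means among the compounds named here.

Measured in a physicochemical assay for solubility; a higher number here means a more soluble compound, a lower number a less soluble compound:
- compound 1 `O=S(=O)(Nc1nccs1)c1ccc2c(c1)OCC[C@H]2c1ccc(C(F)(F)F)cc1-c1nccs1`: 7000 nM
- compound 2 `Cc1ccc(-c2cc(C(F)(F)F)ccc2[C@H]2CCOc3cc(S(=O)(=O)Nc4ncc(F)cn4)ccc32)cn1`: 225000 nM
- compound 3 `O=S(=O)(Nc1ncccn1)c1ccc2c(c1)CC[C@@H]2c1ccc(C(F)(F)F)cc1-c1ccc(F)nc1`: 40000 nM

Compound 1 holds the lowest number of the three, with compound 3 nearest above it and compound 2 furthest. Compound 4 `Cn1nccc1-c1cc(C(F)(F)F)ccc1[C@@H]1CCOc2cc(S(=O)(=O)Nc3nccs3)ccc21` keeps the core of compound 1 and makes one change: 1-methyl-1H-pyrazol-5-yl in place of 1,3-thiazol-2-yl on an aromatic carbon. For the measured compounds named here, no measured pair isolates this change, so the size of the step in this assay is uncertain. A moderate rise is expected, with compound 1 at 7000 nM as the starting point and compound 3 at 40000 nM as a rough guide to its size. The estimated step is a 2.9-fold higher number from compound 1 to compound 4 (0.46 log units; beyond the scatter). For compound 4 the expected value is 20000 nM, with an estimated range of 7000 nM to 70000 nM.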

Compound 4, solubility: 65000 nM
For compound 4 the middle estimate is 3.3-fold (0.51 log units) below the measured one; measured number inside the range.
By their numbers in this assay, from the lowest: compound 1; then compounds 3 and 4 (each within the scatter of the next); then compound 2.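

In this assay, 1-methyl-1H-pyrazol-5-yl in place of 1,3-thiazol-2-yl on an aromatic carbon gives a 9.3-fold higher number from compound 1 to compound 4 (0.97 log units; beyond the scatter) with the shared core held fixed. For the compounds shown here, this is the first single-place step, and it shows that this position alone can move the read-out beyond the scatter, even though both groups are five-membered aromatic rings with 2 hetero atoms. Nothing at hand gives a cause for this step.

Still open, on these data alone, is what an amine or a carboxylic acid at this position would do to the read-out. Also open, as far as these compounds go, is whether the same step holds on the cores of compound 2 and compound 3.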